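From Propylamino to Methoxycarbonyl: An Expected Loss of Potency

The source may hold more compounds than are shown below. What is called first, only, known or untested is meant among the compounds shown, and "the series" means these compounds.

Of the compounds shown here, three with a shared core have been tested in a functional assay on the whole organism with Rattus norvegicus as the target; on this read-out lower numbers stand for an effect already at smaller amounts and higher numbers for an effect only at larger amounts of compound. Compound 3 `CCCNc1cccc(NC(=O)C(=O)OCC)c1C#N` gives 0.7 mg/kg, the lowest of the two numbers shown. Compound 1 `CCOC(=O)C(=O)Nc1ccc(N)cc1C#N` gives 8.8 mg/kg, a higher number lying beyond the usual scatter. For compound 2 `CCOC(=O)C(=O)Nc1cc(N(C)C)ccc1C#N` only a limit of the assay is reported, not a number: compound 2 gives > 100 mg/kg, which is the limit of > 100 mg/kg in this assay, at which 1 of the 3 values shown sits. Compound 4 `CCOC(=O)C(=O)Nc1cccc(C(=O)OC)c1C#N` has not been measured. It differs from compound 3 in one place: methoxycarbonyl in place of propylamino on an aromatic carbon. Going by the values given here, no measured pair shows this exchange, so its size cannot be read from the data. A rise beyond the scatter is expected, since compound 1 gives 8.8 mg/kg without a propylamino group. Compound 4 is therefore estimated at 10 mg/kg in this assay, between 2 mg/kg and 60 mg/kg. The expected step is a 14-fold higher number from compound 3 to compound 4 (1.15 log units; beyond the scatter).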

Compound 4, dose for half-maximal effect: 0.8 mg/kg
Estimate against measurement, compound 4: 13-fold (1.10 log units) above; the whole stated range lies above it.
By their numbers in this assay, from the lowest: compounds 3 and 4 (each within the scatter of the next); then compound 1. At a limit, above all of these: compound 2.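

In this assay placing methoxycarbonyl instead of propylamino on this aromatic carbon, ortho to a cyano group, gives a 1.1-fold higher number from compound 3 to compound 4 (0.06 log units; within the scatter) and leaves the two numbers inseparable. This position therefore accepts a group with no hydrogen-bond donor as well as one with a donor, and propylamino is not needed for a value at this level. Nothing shown accounts for why the two groups read alike. On these data alone, whether a free amine, a carboxylic acid or a longer chain on this carbon would read the same remains open.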